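The compounds below may be only part of what the source reports. "The series", "measured", "known", "first", "only" and "open" are said of these compounds alone.

Of the compounds shown here, two measured so far share a core and differ only in the group on one aromatic carbon. Among the measured compounds shown here, compound 1 `CC(C)c1ccc(S(=O)(=O)c2ccc3[nH]nc(C4CCN(C)CC4)c3c2)cc1` gives 14 nM in an assay on HeLa cells for displacement of a labelled ligand from 5-hydroxytryptamine receptor 6 (Homo sapiens); a lower number here means a stronger inhibitor, a higher number a weaker inhibitor; compound 2 `CN1CCC(c2n[nH]c3ccc(S(=O)(=O)c4ccc(F)cc4)cc23)CC1` gives 66 nM in this assay, the higher of the two numbers, and the single step between them, a 4.7-fold higher number from compound 1 to compound 2 (0.67 log units; beyond the scatter), is modest but beyond the scatter. Compound 3 `CN1CCC(c2n[nH]c3ccc(S(=O)(=O)c4ccc(OC(F)(F)F)cc4)cc23)CC1` has not been measured; it differs from compound 2 by trifluoromethoxy in place of fluoro on an aromatic carbon. For the measured compounds named here, the one measured step bears directly on this change, because a 4.7-fold higher number from compound 1 to compound 2 (0.67 log units; beyond the scatter) altered the same group on the same aromatic carbon, and it ran toward a higher number when isopropyl gave way to fluoro. Trifluoromethoxy is neither of those groups, and no step from fluoro to it has been measured. Compound 3 is therefore expected to give a somewhat lower number than before, a step of a 2.6-fold lower number from compound 2 to compound 3 (0.42 log units; beyond the scatter). For compound 3 the estimate is 25 nM, with a range from 8 nM to 80 nM.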

Compound 3, inhibition constant: 48 nM
The estimate for compound 3 lay 1.9-fold (0.28 log units) below the measured number, and the stated range covers the measured number.
By their numbers in this assay, from the lowest: compound 1; then compounds 3 and 2 (each within the scatter of the next).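

In this assay, trifluoromethoxy in place of fluoro on this aromatic carbon, para to a large group, gives no readable change (a 1.4-fold lower number from compound 2 to compound 3 (0.14 log units; within the scatter)), although 5 heavy atoms and 1 hydrogen-bond acceptor enter where 1 heavy atom leaves. The step away from isopropyl now has a second example (a 3.4-fold higher number from compound 1 to compound 3 (0.54 log units; beyond the scatter)), which runs in the same direction as the step to fluoro and is likewise modest. Across these compounds, then, isopropyl stands apart from two quite different replacements, which themselves cannot be told apart here. Nothing available explains why these groups read as they do.

The compounds shown leave open whether isopropyl's number is shared by other carbon groups, such as a tert-butyl group or a longer chain. They also leave open how an amine or a carboxylic acid on this carbon would read.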